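Rearranging the Ester Side Chain of Compound 3

The source may hold more compounds than are shown below. What is called first, only, known or untested is meant among the compounds shown, and "the series" means these compounds.

Of the compounds shown here, three sharing one core have been measured in a functional assay on DU-145 cells (Homo sapiens) for cytotoxicity, read by MTT assay; on this read-out higher numbers stand for weaker inhibition and lower numbers for stronger inhibition. Compound 1 `CC(C)=CC[C@@H](OC[C@H](C)O)C1=CC(=O)c2c(O)ccc(O)c2C1=O` gives 24500 nM. Compound 2 `COC(C)CO[C@H](CC=C(C)C)C1=CC(=O)c2c(O)ccc(O)c2C1=O` gives 16600 nM, and compound 3 `CC(C)=CC[C@@H](OC(=O)CC(C)(O)C(C)C)C1=CC(=O)c2c(O)ccc(O)c2C1=O` gives 16900 nM. Compound 3 stands at the second highest of the three numbers; its nearest neighbour is compound 2, its furthest is compound 1, and neither gap leaves the scatter.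

Compound 4 `CCC(O)(CC)CC(=O)O[C@H](CC=C(C)C)C1=CC(=O)c2c(O)ccc(O)c2C1=O` differs from compound 3 only in the ester side chain: 1-ethyl-1-hydroxypropyl in place of 1-hydroxy-1,2-dimethylpropyl on a saturated chain carbon bound to a carbonyl carbon. The two measured steps that reach compound 3 both altered this same side chain. The step of a 1.4-fold lower number from compound 1 to compound 3 (0.16 log units; within the scatter) and the step of a 1.0-fold higher number from compound 2 to compound 3 (0.01 log units; within the scatter) were each within the scatter, even though those changes replaced the whole group rather than rearranging it. For the measured compounds named here, nothing among the measured compounds points to a step beyond the scatter in this assay for a change of this kind. Compound 4 is therefore expected to land close to compound 3, with the estimated step of a 1.0-fold higher number from compound 3 to compound 4 (0.00 log units; within the scatter), giving an estimate of 17000 nM with a range from 8000 nM to 36000 nM.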

Compound 4, half-maximal inhibitory concentration: 67000 nM
Beside the measured number, compound 4's estimate is 3.9-fold (0.60 log units) below it, and the stated range ends below it.
By their numbers in this assay, from the lowest: compounds 2, 3 and 1 (each within the scatter of the next); then compound 4.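

In this assay, for the compounds shown here, this position proves sensitive to how the atoms of the side chain are joined, not only to which group is present: with the same atoms, 1-ethyl-1-hydroxypropyl in place of 1-hydroxy-1,2-dimethylpropyl gives a 4.0-fold higher number from compound 3 to compound 4 (0.60 log units; beyond the scatter) and so passes the scatter, which no step among the earlier compounds did. The (2-ethyl-2-hydroxybutyl)carbonyl group also separates from 2-methoxypropyl, with a 4.0-fold higher number from compound 2 to compound 4 (0.61 log units; beyond the scatter), and from 2-hydroxypropyl, with a 2.7-fold higher number from compound 1 to compound 4 (0.44 log units; beyond the scatter), which leaves compound 4 as the weakest of the four. Nothing available accounts for this difference.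

The compounds shown leave open whether a longer chain on the same saturated carbon, such as 1-hydroxy-1-propylbutyl, would raise the number further. They also leave open what an amine in place of the hydroxy group there would do.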